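From a Methylphenyl to a Naphthyl Terminus

This account rests on a few compounds, and the source may have more. Where it says the series, first, only, none or still open, it means among the compounds named here.

Measured compounds:
Compound 1, `CN1CCN(c2ccc3[nH]c(-c4ccc5[nH]c(-c6ccccc6)nc5c4)nc3c2)CC1`: 490 nM
Compound 2, `Cc1cccc(-c2nc3cc(-c4nc5cc(N6CCN(C)CC6)ccc5[nH]4)ccc3[nH]2)c1`: 360 nM

The two measured compounds share one core and differ only in the group attached to it. In a functional assay on RPMI 8402 cells (Homo sapiens) for cytotoxicity (a lower number here means a stronger inhibitor, a higher number a weaker inhibitor), compound 1 gives 490 nM, and compound 2 gives 360 nM. Compound 2 holds the lowest of the two numbers, with compound 1 as its nearest neighbour; the step of a 1.4-fold lower number from compound 1 to compound 2 (0.13 log units; within the scatter) is the only one on record, and it lies within the scatter, so the two compounds cannot be ordered against each other.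

Compound 3, `CN1CCN(c2ccc3[nH]c(-c4ccc5[nH]c(-c6ccc7ccccc7c6)nc5c4)nc3c2)CC1`, continues from compound 2 by the change (naphthalen-2-yl in place of 3-methylphenyl on an aromatic carbon). Going by the values given here, the single measured step bears on it directly, since it also altered the same terminal group, yet it produced no shift beyond the scatter. On that evidence alone, no movement beyond the scatter is expected for compound 3 in this assay, with a 1.2-fold lower number from compound 2 to compound 3 (0.08 log units; within the scatter) as the anticipated step. Compound 3 is therefore estimated at 300 nM, within a range from 120 nM to 800 nM.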

Compound 3, half-maximal inhibitory concentration: 110 nM
Compound 3: the middle estimate sits 2.7-fold (0.44 log units) above what was measured; the measured number lies below the stated range.
By their numbers in this assay, from the lowest: compound 3; then compounds 2 and 1 (each within the scatter of the next).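

At this position, on an aromatic carbon of a five-membered aromatic ring with 2 nitrogen, between two ring nitrogen atoms, the earlier pair had shown no shift in this assay that could be told from the scatter, but the terminal group does matter once a second six-membered aromatic ring of carbon is present. Replacing 3-methylphenyl with naphthalen-2-yl moves the number beyond the scatter (a 3.3-fold lower number from compound 2 to compound 3 (0.51 log units; beyond the scatter)), and replacing phenyl with the same group does so too (a 4.5-fold lower number from compound 1 to compound 3 (0.65 log units; beyond the scatter)), so compound 3 stands apart from both earlier compounds, whereas adding a methyl to the phenyl group gave no readable change. Nothing measured here accounts for this difference between the two kinds of change.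

The three compounds cannot show whether the number depends on the added aromatic ring itself or simply on the larger group of 10 heavy atoms, and they leave open how a terminal phenyl carrying an amine or a carboxylic acid would behave. Going by these compounds, all three values also come from this assay alone, so whether the step from 3-methylphenyl to naphthalen-2-yl holds in any other setting remains unknown.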